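The source may report more compounds than this note shows. Statements on the series, on what has been measured and on what is new or still open speak of the compounds shown alone.

Measured compounds:
compound 1 `COc1cc(C(=O)c2sc(-c3ccc(C)cc3)cc2N)cc(OC)c1OC` — 16 nM
compound 2 `COc1cc(C(=O)c2sc(-c3ccccc3)cc2N)cc(OC)c1OC` — 13 nM

In a functional assay on FM3A cells (Mus musculus) for antiproliferative activity (a lower number here means a stronger inhibitor, a higher number a weaker inhibitor), compound 1 gives 16 nM and compound 2 gives 13 nM; the step of a 1.2-fold lower number from compound 1 to compound 2 (0.09 log units; within the scatter) lies within the scatter, so compound 2 stands level with compound 1 on the two numbers shown. Compound 3 `COc1cc(C(=O)c2sc(-c3ccc(-c4ccccc4)cc3)cc2N)cc(OC)c1OC` is not yet measured. It differs from compound 2 by phenyl in place of hydrogen on an aromatic carbon. Among the measured compounds shown here, the only step at that carbon, a 1.2-fold lower number from compound 1 to compound 2 (0.09 log units; within the scatter), was small, but no measured step covers a group of this size there, so the series gives little guidance. The expected step is a 2.3-fold higher number from compound 2 to compound 3 (0.36 log units; beyond the scatter), a slightly higher number. Compound 3 is expected near 30 nM, within 8 nM to 120 nM.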

Compound 3, half-maximal inhibitory concentration: > 10000 nM
Compound 3: no number, only a limit; the forecaster's own chance of this, stated with the estimate: 5%; at least 330-fold (2.52 log units) between middle value and limit.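

In this assay compound 3 reads > 10000 nM, which is a limit of the assay and not a number. Hydrogen and methyl on this aromatic carbon stand level, whereas phenyl there gives an at least 760-fold higher number from compound 2 to compound 3 (2.88 log units; beyond the scatter) and an at least 620-fold higher number from compound 1 to compound 3 (2.79 log units; beyond the scatter). The position therefore does not accept every group, which the first two compounds could not show, and the true size of both steps stays hidden behind the limit.

The compounds shown leave open where between methyl and phenyl the loss begins. As far as these compounds go, it is also open whether an ethyl, a methoxy or a morpholine on this carbon behaves like methyl or like phenyl.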